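Swapping cyclohexyl for 2-bromophenyl on the sulfanyl chain

A few compounds are considered here, and "the series" means these few. Any claim that something is new, unique, unknown or untested is made for them only; others in the source may bear on it.

This account concerns a small set of compounds sharing one core, tested in an ADME assay on GES1 cells (Homo sapiens) for inhibition, read by MTT assay, with a stated time of 72 h; on this read-out higher numbers stand for weaker inhibition and lower numbers for stronger inhibition. Compound 1 `Cc1cc(Nc2cc(-c3ccccc3)[nH]n2)n2nc(SCc3ccc([N+](=O)[O-])cc3)nc2n1` carries a 4-nitrophenyl group on the saturated chain carbon bound to a sulfur, and in this assay compound 1 gives 43600 nM. Compound 2 `Cc1cc(Nc2cc(-c3ccccc3)[nH]n2)n2nc(SCC3CCCCC3)nc2n1` carries a cyclohexyl group at the same place. For compound 2 the read-out in this assay is only a limit, > 50000 nM, so its true value is not known as a number. Measured as a step, the change gives an at least 1.1-fold higher number from compound 1 to compound 2 (0.05 log units; that floor lies within the scatter), and this step is the only one available; it sits at the limit of > 50000 nM in this assay, at which 1 of the 2 values shown sits.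

Compound 3 `Cc1cc(Nc2cc(-c3ccccc3)[nH]n2)n2nc(SCc3ccccc3Br)nc2n1` is not yet measured. It differs from compound 2 in one place: 2-bromophenyl in place of cyclohexyl on a saturated chain carbon bound to a sulfur. The step from compound 1 to compound 2 exchanged an aromatic ring for cyclohexyl without a change beyond the scatter, and the step to compound 3 reverses that kind of exchange. No shift beyond the scatter is therefore expected, and the step from compound 2 to compound 3 is estimated at an at least 1.1-fold lower number from compound 2 to compound 3 (0.04 log units; that floor lies within the scatter). In this assay compound 3 is expected to give about 45000 nM, within a range from 20000 nM to 100000 nM.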

Compound 3, half-maximal inhibitory concentration: 41100 nM
Compound 3: middle estimate off by 1.1-fold (0.04 log units), on the high side, and the stated range covers the measured number.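

With compound 3, a second aromatic group at this place can be compared with the first: in this assay, 2-bromophenyl in place of 4-nitrophenyl on a saturated chain carbon bound to a sulfur gives a 1.1-fold lower number from compound 1 to compound 3 (0.03 log units; within the scatter). This assay therefore does not separate these two substituted aromatic rings, although one carries a bromine and the other a nitro group. The comparison with the non-aromatic ring gains a second step, an at least 1.2-fold lower number from compound 2 to compound 3 (0.08 log units; that floor lies within the scatter), but this is only a floor within the scatter, so neither exchange between cyclohexyl and an aromatic ring shows a change that can be sized, and compound 2 still has a limit and not a number: the limit of > 50000 nM in this assay, at which 1 of the 3 values shown sits.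

The compounds shown leave open whether an unsubstituted phenyl group on the same carbon would read like compound 1 and compound 3. They also leave open whether a longer chain between the sulfur and the ring, or an amine or a carboxylic acid in place of the ring, would move the number beyond the scatter.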